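Changing the Side Chain: An Estimate for Compound 3

The source may hold more compounds than are shown below. What is called first, only, known or untested is meant among the compounds shown, and "the series" means these compounds.

Compound 1, `C=C1CC[C@H]2C(C)(C)CCC[C@]2(C)[C@H]1C/C=C(/C=O)CCO`: > 50000 nM
Compound 2, `C=C1CC[C@H]2C(C)(C)CCC[C@]2(C)[C@H]1/C=C/C(=O)O`: 23700 nM

In a functional assay on RAW264.7 cells (Mus musculus) for inhibition, with a stated time of 24 h (on this read-out lower numbers stand for stronger inhibition and higher numbers for weaker inhibition), compound 2 gives 23700 nM. For compound 1 the result in this assay is > 50000 nM, which is a limit of the assay rather than a number. For the measured compounds named here, compound 2 therefore holds the only actual number here, and that number describes weak inhibition.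

Compound 3, `C=C1CC[C@H]2C(C)(C)CCC[C@]2(C)[C@H]1C/C=C(/C=O)CO`, has not yet been measured. It differs from compound 2 in one place: a group of 7 heavy atoms (5 carbon, 2 oxygen; no ring) in place of a group of 5 heavy atoms (3 carbon, 2 oxygen; no ring), on a saturated ring carbon. The group that enters resembles the side chain of compound 1. Compound 1, carrying that related chain, sits at the limit of > 50000 nM in this assay, at which 1 of the 2 values shown sits, in this assay. On that basis compound 3 is expected to show a weakening step of about a 1.7-fold higher number from compound 2 to compound 3 (0.23 log units; within the scatter) in this assay. Compound 3 is estimated at 40000 nM in this assay, within a range of 15000 nM to 100000 nM, with a real chance that only a limit is reported.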

Compound 3, half-maximal inhibitory concentration: 28700 nM
Beside the measured number, compound 3's estimate is 1.4-fold (0.14 log units) above it, and the stated range covers the measured number.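

On this saturated ring carbon, the 2-carboxyethenyl group can give way to a larger side chain ending in hydroxy, and this assay shows only a 1.2-fold higher number from compound 2 to compound 3 (0.08 log units; within the scatter), so the two groups cannot be told apart here. Hydroxy in place of hydroxymethyl at the chain end gives an at least 1.7-fold lower number from compound 1 to compound 3 (0.24 log units; that floor lies within the scatter), but that figure is only a floor, so it cannot show whether this small edit matters. Compound 1 remains a limit and not a number: the limit of > 50000 nM in this assay, at which 1 of the 3 values shown sits.

Going by these compounds, compound 2 and compound 3 both show weak inhibition, so it remains open whether any group on this carbon can bring the number down beyond the scatter. An amine or a methyl ether at the chain end, or a longer chain, could help to answer that.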